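Same Chain Extension Tried on a Second Core

The compounds below may be only part of what the source reports. "The series", "measured", "known", "first", "only" and "open" are said of these compounds alone.

Compound 1, `CCCn1c(Br)nc2c(N)nc(NCc3ccccc3)nc21`: 650 nM
Compound 2, `CCCn1c(Br)nc2c(N)nc(NCCCc3ccccc3)nc21`: 1950 nM
Compound 3, `CCCn1c(-c2ccco2)nc2c(NCc3ccccc3)ncnc21`: 402 nM

These three compounds were measured in an assay on CHO cells for displacement of a labelled ligand from transmembrane domain-containing protein TMIGD3 (Homo sapiens); on this read-out higher numbers stand for weaker inhibition and lower numbers for stronger inhibition. Between compound 1 and compound 2 the change is phenethyl in place of phenyl on a saturated chain carbon bound to a nitrogen on an aromatic ring, and it produced a 3.0-fold higher number from compound 1 to compound 2 (0.48 log units; beyond the scatter). Compound 3 carries a different core; the difference between the two cores is not broken down here, and compound 3 and compound 1 differ only within the scatter. Compound 4, `CCCn1c(-c2ccco2)nc2c(NCCCc3ccccc3)ncnc21`, applies the same change to the core of compound 3: phenethyl in place of phenyl on a saturated chain carbon bound to a nitrogen on an aromatic ring, at a place described in the same words as before. With one earlier example, the step is expected to be a 3.0-fold higher number from compound 3 to compound 4 (0.47 log units; beyond the scatter) because the same change on the core of compound 1 gave a 3.0-fold higher number from compound 1 to compound 2 (0.48 log units; beyond the scatter). Compound 4 is therefore estimated at 1200 nM, with a range from 600 nM to 2500 nM.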

Compound 4, inhibition constant: 959 nM
Estimate against measurement, compound 4: 1.3-fold (0.10 log units) above; the range from low to high includes it.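

In this assay, replacing benzyl with 3-phenylpropyl on the core of compound 3 gave a 2.4-fold higher number from compound 3 to compound 4 (0.38 log units; beyond the scatter), so the weaker binding seen on the first core appeared on the second as well. The two steps agree in direction and, within the scatter, in size: the same change on two cores in this assay, a 3.0-fold higher number (0.48 log units; beyond the scatter) from compound 1 to compound 2 and a 2.4-fold higher number (0.38 log units; beyond the scatter) from compound 3 to compound 4, 1.3-fold (0.10 log units) apart, within the scatter of two such steps. This shows that the change carried over between these two cores, but two pairs cannot show that it would hold on any other core, and they do not explain why the number rises.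

The compounds shown leave open how a chain longer than 3-phenylpropyl would read. They also leave open whether an amine or a carboxylic acid on the phenyl ring would alter the step.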